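A Fluoro Group Added to Compound 2

A few compounds are considered here, and "the series" means these few. Any claim that something is new, unique, unknown or untested is made for them only; others in the source may bear on it.

In a functional assay on CCRF-CEM cells (Homo sapiens) for inhibition, read by MTT assay, with a stated time of 72 h (a lower number here means a stronger inhibitor, a higher number a weaker inhibitor), compound 1 `COc1cc(NC(=O)/C=C/c2cccc(OCc3ccccc3)c2)cc(OC)c1OC` gives 17300 nM and compound 3 `C=C(Br)C(=O)Nc1cccc(/C=C/C(=O)Nc2cccc3ccccc23)c1` gives 1800 nM. Compound 2 `C=C(Br)C(=O)Nc1cccc(/C=C/C(=O)Nc2ccccc2)c1` gives 190 nM, the lowest of the three numbers, and its gaps to both others lie beyond the scatter.

Compound 4 `C=C(Br)C(=O)Nc1cccc(/C=C/C(=O)Nc2ccc(F)cc2)c1` differs from compound 2 in one place: fluoro in place of hydrogen on an aromatic carbon. This is fluoro in place of hydrogen on an aromatic carbon, para to a large group. Among the compounds with values here, no measured pair shows this change, so the expectation rests only on how small the change is. In this assay an estimated 1.2-fold higher number from compound 2 to compound 4 (0.06 log units; within the scatter) is expected, which would be no step beyond the scatter. The expected value for compound 4 is 220 nM, with a likely range from 80 nM to 600 nM.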

Compound 4, half-maximal inhibitory concentration: 16600 nM
Compound 4: the middle estimate sits 75-fold (1.88 log units) below what was measured, outside the stated range (above it).
By their numbers in this assay, from the lowest: compound 2; then compound 3; then compounds 4 and 1 (each within the scatter of the next).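

In this assay, fluoro in place of hydrogen gives an 87-fold higher number from compound 2 to compound 4 (1.94 log units; beyond the scatter), so this place on the phenyl ring is sensitive to a change of a single atom. The earlier compounds shown here held no pair differing in one place and could not show this. Nothing measured here accounts for the rise.

On these data alone, it remains open whether the loss is specific to fluoro or would also follow from another group here, such as chloro, methoxy or an amine. As far as these compounds go, it is also open whether fluoro on another aromatic carbon of this ring would act the same way.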